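A few compounds are considered here, and "the series" means these few. Any claim that something is new, unique, unknown or untested is made for them only; others in the source may bear on it.

Compound 1 `CNC(=O)[C@@]12C[C@@H]1[C@@H](n1cnc3c(NCc4cccc(Cl)c4)nc(C#CCCCCc4cn(-c5ccc(N)cc5)nn4)nc31)[C@H](O)[C@@H]2O`: 3%
Compound 2 `CNC(=O)[C@@]12C[C@@H]1[C@@H](n1cnc3c(NCc4cccc(Cl)c4)nc(C#CCCCCc4cn(Cc5ccc(-n6sccc6=O)cc5)nn4)nc31)[C@H](O)[C@@H]2O`: 15%

Both compounds were tested in an assay on CHO cells for displacement of a labelled ligand from adenosine receptor A1 (Homo sapiens), read by scintillation counting, tested at 10 uM; a higher number here means more inhibition at the concentration tested (going by the name of the read-out), a lower number less inhibition. Compound 1 stands lowest of the two numbers; the nearest is compound 2, which lies above it by a margin beyond the usual scatter of repeated measurements. Compound 3 `C#CCCCCC#Cc1nc(NCc2cccc(Cl)c2)c2ncn([C@H]3[C@H](O)[C@H](O)[C@]4(C(=O)NC)C[C@H]34)c2n1` has not yet been measured in this assay. It differs from compound 1 in one place: ethynyl in place of 1-(4-aminophenyl)-1H-1,2,3-triazol-4-yl on a saturated chain carbon, four bonds along the chain from a triple-bonded carbon. Going by the values given here, the two measured compounds differ from each other in more than one place, so no single step between them can be read, and the two values only show that both sit low in this assay. On that basis compound 3 is expected to stay low as well, and the step of a number 2 percentage points higher from compound 1 to compound 3 (within the scatter) is expected to be small, not beyond the scatter. The estimate for compound 3 in this assay is 5%, with a range from -5% to 20%.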

Compound 3, a percentage reported as inhibition, at one concentration (the size of the read-out at that concentration, not a potency): 31%
Beside the measured number, compound 3's estimate is 26 percentage points below it; measured number outside the range, above it.
By their numbers in this assay, from the lowest: compound 1; then compound 2; then compound 3.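

In this assay, the place on a saturated chain carbon, four bonds along the chain from a triple-bonded carbon, turns out to affect the read-out: ethynyl in place of 1-(4-aminophenyl)-1H-1,2,3-triazol-4-yl gives a number 28 percentage points higher from compound 1 to compound 3 (beyond the scatter). Going by these compounds alone, this is the only change in a single place that can be read so far, as the other pair differs in more than one place. It shows that the two aromatic rings of the group that leaves are not required for this level of inhibition, although nothing shown here accounts for the rise.

The compounds shown leave open whether the rise comes from losing the triazole group or from gaining the ethynyl, a question that a plain methyl, an amine or a carboxylic acid at this place could help settle. They also leave open how these single-concentration percentages would translate into potency.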